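This account rests on a few compounds, and the source may have more. Where it says the series, first, only, none or still open, it means among the compounds named here.

Working notes on the series in an assay on isolated protein for inhibition of Indoleamine 2,3-dioxygenase 1 (Homo sapiens), read by spectrophotometry; a lower number here means a stronger inhibitor, a higher number a weaker inhibitor.

Of the compounds shown here, three have numbers so far. Compound 1 `O=C(Cc1cccnc1)c1cc2c(F)cccc2[nH]1` gives 153000 nM, compound 2 `O=C(Cc1cccnc1)c1cc2cc(-c3ccccc3)ccc2[nH]1` gives 96000 nM, and compound 3 `O=C(Cc1cccnc1)c1cc2ccccc2[nH]1` gives 65000 nM. Compound 3 holds the lowest of the three numbers, but only the gap to compound 1 is beyond the scatter: the step of a 2.4-fold lower number from compound 1 to compound 3 (0.37 log units; beyond the scatter) is modest and clear, whereas the step of a 1.5-fold lower number from compound 2 to compound 3 (0.17 log units; within the scatter) stays within the scatter, so compound 2 and compound 3 cannot be ordered against each other.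

The next compound, compound 4 `O=C(Cc1cccnc1)c1cc2cc(Br)ccc2[nH]1`, differs from compound 3 by bromo in place of hydrogen on an aromatic carbon. Among the measured compounds shown here, no measured step involves bromo. The two measured steps both replace a group on an aromatic carbon with hydrogen; the removal of fluoro in compound 1 gave the modest step of a 2.4-fold lower number from compound 1 to compound 3 (0.37 log units; beyond the scatter), and the removal of phenyl in compound 2 gave the step of a 1.5-fold lower number from compound 2 to compound 3 (0.17 log units; within the scatter), which is within the scatter. Given that the larger substituent in compound 2 left the number essentially unchanged, the expected step of no change at the digits printed from compound 3 to compound 4 (within the scatter) for compound 4 is small and may not clear the scatter in either direction. Compound 4 is therefore estimated at 65000 nM, with a range from 25000 nM to 160000 nM.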

Compound 4, half-maximal inhibitory concentration: 18000 nM
Compound 4: middle estimate off by 3.6-fold (0.56 log units), on the high side; measured number below the stated range.
By their numbers in this assay, from the lowest: compound 4; then compounds 3, 2 and 1 (each within the scatter of the next, the first and the last beyond it).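

In this assay the position that carries bromo in compound 4 and phenyl in compound 2 now shows a substituent giving a lower number than hydrogen, a step beyond the scatter (a 3.6-fold lower number from compound 3 to compound 4 (0.56 log units; beyond the scatter)). The position also separates two substituents (a 5.3-fold lower number from compound 2 to compound 4 (0.73 log units; beyond the scatter)), while phenyl stays within the scatter of hydrogen (a 1.5-fold lower number from compound 2 to compound 3 (0.17 log units; within the scatter)), so the outcome here depends on which group is attached and not simply on whether the hydrogen is replaced. Nothing available on these compounds accounts for the difference between bromo and phenyl at this position.

As far as these compounds go, it remains open whether the lower number is particular to bromo or extends to chloro, iodo or methyl at this position, and how an amine or a carboxylic acid there would read. The fluoro of compound 1 stands at another place on the core, so the compounds shown do not tell how fluoro would read at the bromo position, or bromo at the fluoro position.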